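Swapping an aromatic ring for a pentyl chain in an ecdysone agonist

The compounds below may be only part of what the source reports. "The series", "measured", "known", "first", "only" and "open" are said of these compounds alone.

Measured so far:
compound 1 `CC(C)(C)N(NC(=O)c1ccc(F)cc1)C(=O)c1ccccc1Cl`: 389 nM
compound 2 `CCc1ccc(C(=O)NN(C(=O)c2ccccc2Cl)C(C)(C)C)cc1`: 5.75 nM

In an assay on cells for agonist activity at ecdysone receptor (Bombyx mori), read by a luciferase reporter, with a stated time of 24 h (a lower number here means that less compound is needed, a higher number that more compound is needed for the effect), compound 2 gives the lowest of the two numbers shown, with compound 1 the nearest at a 68-fold lower number from compound 1 to compound 2 (1.83 log units; beyond the scatter). Compound 3 `CCCCCC(=O)N(NC(=O)c1ccc(CC)cc1)C(C)(C)C` differs from compound 2 by pentyl in place of 2-chlorophenyl on a carbonyl carbon. Within the data shown here, no measured step touches this carbonyl carbon; the only step known concerns the other ring. The change replaces a ring with a chain, a larger alteration than the one measured, so a loss is expected: compound 3 is estimated at 150 nM, between 20 nM and 1200 nM, a step of a 26-fold higher number from compound 2 to compound 3 (1.42 log units; beyond the scatter).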

Compound 3, half-maximal effective concentration: 2820 nM
Beside the measured number, compound 3's estimate is 19-fold (1.27 log units) below it, and the stated range ends below it.
By their numbers in this assay, from the lowest: compound 2; then compound 1; then compound 3.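

The carbonyl carbon, untouched by the earlier pair, turns out to be just as sensitive as the other ring: in this assay, pentyl in place of 2-chlorophenyl gives a 490-fold higher number from compound 2 to compound 3 (2.69 log units; beyond the scatter). So at this place, with the ethyl group of compound 2 kept, a five-carbon chain does not stand in for the 2-chlorophenyl ring. No available evidence explains this loss.

From the compounds shown here alone, it remains open whether the ring or its chlorine matters more. A plain phenyl group, or a cyclohexyl ring, at this carbonyl carbon would help separate the two.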